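A few compounds are considered here, and "the series" means these few. Any claim that something is new, unique, unknown or untested is made for them only; others in the source may bear on it.

Measured compounds:
- compound 1 `CC(=O)NCCCCc1ccc2ncn(-c3ccnc(N)n3)c2c1`: in an assay on Sf9 cells for inhibition of mitogen-activated protein kinase kinase kinase 14 variant S549D (Homo sapiens), with a stated time of 30 min, in the presence of a further agent that is not named here (on this read-out higher numbers stand for weaker inhibition and lower numbers for stronger inhibition), compound 1 gives 398000 nM
- compound 2 `C#Cc1cc(C#Cc2ccc3ncn(-c4ccnc(N)n4)c3c2)ccn1`: in this assay compound 2 gives 31600 nM

Of the two measured compounds, compound 2 stands with the lower number in this assay, and compound 1 with the higher; the gap between them is beyond the usual scatter of this kind of measurement, so compound 2 is the stronger inhibitor of the pair on this read-out. The two differ in more than one place, so the numbers alone say nothing about which part of the structure accounts for the gap.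

Compound 3 `C=Cc1ccc(C#Cc2ccc3ncn(-c4ccnc(N)n4)c3c2)cn1` is not yet measured. It keeps the shared core and the triple bond of compound 2 and differs only at the far end: a group of 8 heavy atoms (7 carbon, 1 nitrogen; one six-membered aromatic ring with 1 hetero atom) in place of a group of 8 heavy atoms (7 carbon, 1 nitrogen; one six-membered aromatic ring with 1 hetero atom), on a triple-bonded carbon. Both the leaving and the entering group are a six-membered aromatic ring with one nitrogen carrying a small two-carbon substituent, so the change is a rearrangement of like for like rather than a gain or loss of bulk.

For the measured compounds named here, with no measured pair of this kind to draw on, the expected step from compound 2 to compound 3 in this assay is a 1.3-fold higher number from compound 2 to compound 3 (0.10 log units; within the scatter), which is within the scatter, in no firm direction. The expected value of compound 3 in this assay is therefore estimated at 40000 nM, within a range of 10000 nM to 160000 nM.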

Compound 3, half-maximal inhibitory concentration: 79400 nM
Beside the measured number, compound 3's estimate is 2.0-fold (0.30 log units) below it; low and high end bracket the measured number.
By their numbers in this assay, from the lowest: compound 2; then compound 3; then compound 1.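

In this assay, for the compounds shown here, the first comparison that changes only one place gives a 2.5-fold higher number from compound 2 to compound 3 (0.40 log units; beyond the scatter), so this position, on a triple-bonded carbon, is sensitive even to a swap of like for like. The exchange keeps the number of heavy atoms, the six-membered aromatic ring with its single nitrogen, and the counts of hydrogen-bond donors and acceptors, yet the outcome still moves beyond the scatter, a step that is modest in size and favours the group of compound 2 over the 6-vinylpyridin-3-yl group of compound 3. Nothing available here explains why the exchange has this effect.

The two groups differ both in the triple or double bond of the two-carbon substituent and in the arrangement of the ring, so the compounds shown cannot tell which of these differences carries the step. Going by these compounds, it also remains open how this position would respond to a group of another kind, such as an ethyl group on the pyridine ring, an amine or a carboxylic acid.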